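Adding a Second Furan Ring to Compound 2

This account rests on a few compounds, and the source may have more. Where it says the series, first, only, none or still open, it means among the compounds named here.

Measured so far in an assay on cells for displacement of a labelled ligand from transmembrane domain-containing protein TMIGD3 (Homo sapiens), read by scintillation counting, with a stated time of 120 min, tested at 1 uM; on this read-out lower numbers stand for less inhibition and higher numbers for more inhibition at the one concentration tested (going by the name of the read-out):
compound 1 `COc1ccc(-c2cn3ccnc(N)c3n2)cc1`: 1%
compound 2 `Nc1nccn2cc(-c3ccco3)nc12`: 5%
compound 3 `O=C(Nc1nccn2cc(-c3ccccc3)nc12)c1cccnc1`: 42%

Compound 2 stands second highest of these three numbers. Its value lies within the scatter of compound 1, so the two cannot be told apart, while compound 3 lies beyond the scatter above both. Compound 4 `Nc1nc(-c2ccco2)cn2cc(-c3ccco3)nc12` has not yet been measured. It differs from compound 2 in one place: furan-2-yl in place of hydrogen on an aromatic carbon. The entering group sits meta to the amino group and para to a fused ring. Within the data shown here, no step between two measured compounds is available, so the effect of such an addition cannot be read from the data. Compound 4 is therefore expected to move by a number 5 percentage points higher from compound 2 to compound 4 (within the scatter) in this assay, a change inside the scatter. Compound 4 is estimated at 10%, with a range from 0% to 30%.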

Compound 4, a percentage reported as inhibition, at one concentration (the size of the read-out at that concentration, not a potency): 38%
Compound 4: the middle estimate sits 28 percentage points below what was measured; the whole stated range lies below it.
By their numbers in this assay, from the lowest: compounds 1 and 2 (each within the scatter of the next); then compounds 4 and 3 (each within the scatter of the next).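

Measured in this assay the entry of furan-2-yl in place of hydrogen on this aromatic carbon gives a number 33 percentage points higher from compound 2 to compound 4 (beyond the scatter) and is a large step. Among these compounds, it is the first change in one place that can be read, and it shows that the read-out responds to what sits on this carbon, meta to the amino group. Nothing measured here gives a cause for the rise. On these data alone, whether a methyl group, a thiophene ring or an amine on the same carbon would give a similar step stays open.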